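From diisopropylamino to a silicon group on the shared core

The compounds below may be only part of what the source reports. "The series", "measured", "known", "first", "only" and "open" are said of these compounds alone.

Of the compounds shown here, two on the shared core have been measured. In a functional assay on SW480 cells (Homo sapiens) for antiproliferative activity, read by MTT assay, with a stated time of 48 h (on this read-out higher numbers stand for weaker inhibition and lower numbers for stronger inhibition), compound 1 (`CCN(CC)C/C1=C/C[C@](C)(CCC=C(C)C)/C=C/[C@@H](OC(=O)C=C(C)C)[C@](C)(O)/C=C/C1=O`) gives 270 nM while compound 2 (`CC(C)=CCC[C@]1(C)/C=C/[C@@H](OC(=O)C=C(C)C)[C@](C)(O)/C=C/C(=O)/C(CN(C(C)C)C(C)C)=C\C1`) gives 750 nM and so stands highest of the two, with the weaker inhibition. The change to compound 3 (`CC[Si](CC)(CC)C/C1=C/C[C@](C)(CCC=C(C)C)/C=C/[C@@H](OC(=O)C=C(C)C)[C@](C)(O)/C=C/C1=O`) is a group of 7 heavy atoms (6 carbon, 1 silicon; no ring) in place of a group of 7 heavy atoms (6 carbon, 1 nitrogen; no ring), on a saturated chain carbon bound to a double-bonded ring carbon and it removes the diisopropylamino group. Within the data shown here, only one measured step bears on this, namely a 2.8-fold higher number from compound 1 to compound 2 (0.44 log units; beyond the scatter) on swapping diethylamino for diisopropylamino. Among the measured compounds shown here, both ends of that step carry an amino group and no measured compound contains silicon, so it gives no direction here. No shift beyond the scatter is therefore expected in this assay for this change. The expected step is a 1.3-fold lower number from compound 2 to compound 3 (0.10 log units; within the scatter) on this estimate. For compound 3 the estimated value is 600 nM with an expected range from 170 nM to 2100 nM on this read-out.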

Compound 3, half-maximal inhibitory concentration: 2690 nM
Compound 3: middle estimate off by 4.5-fold (0.65 log units), on the low side; measured number outside the range, above it.
By their numbers in this assay, from the lowest: compound 1; then compound 2; then compound 3.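

In this assay, replacing diisopropylamino with a silicon group of equal heavy-atom count, on a saturated chain carbon bound to a double-bonded ring carbon, gives a 3.6-fold higher number from compound 2 to compound 3 (0.55 log units; beyond the scatter) and so shows that this place responds to more than the count of heavy atoms. Measured against diethylamino, the same silicon group gives a 10-fold higher number from compound 1 to compound 3 (1.00 log units; beyond the scatter) and leaves both amino compounds with lower numbers than compound 3, a gap larger than the one separating the two amines. No available evidence explains this shift.

The compounds shown leave open how a smaller amine such as dimethylamino, or a ring amine such as piperidine, would read at this place. Also open, from the compounds shown here alone, is how an all-carbon group of the same size would read, which would separate the loss of nitrogen from the entry of silicon.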